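Swapping an Imidazole for an Acetamide Side Chain

A few compounds are considered here, and "the series" means these few. Any claim that something is new, unique, unknown or untested is made for them only; others in the source may bear on it.

Compound 1, `Cc1c(F)c(Oc2cccc(C(=N)N)c2)nc(Oc2cccc(C(=O)O)c2)c1F`: > 5000 nM (a limit)
Compound 2, `Cc1c(F)c(Oc2cccc(NS(C)(=O)=O)c2)nc(Oc2cccc(C(=N)N)c2)c1F`: 1900 nM
Compound 3, `Cc1c(F)c(Oc2cccc(C(=N)N)c2)nc(Oc2cccc(-n3ccnc3)c2)c1F`: 4800 nM

Three compounds share one core and differ only in a single group on an aromatic carbon. In an assay on isolated protein for inhibition of serine protease 1 (Bos taurus) (on this read-out higher numbers stand for weaker inhibition and lower numbers for stronger inhibition), compound 1 reaches only the limit of > 5000 nM, so no number is known for it. Compound 2 gives 1900 nM. Compound 3 gives 4800 nM, the highest of the two numbers shown; the step of a 2.5-fold higher number from compound 2 to compound 3 (0.40 log units; beyond the scatter) separates it from its nearest neighbour, beyond the scatter, while the step of an at least 1.0-fold lower number from compound 1 to compound 3 (0.01 log units; that floor lies within the scatter) cannot be told from the scatter because compound 1 is a limit (the limit of > 5000 nM in this assay, at which 1 of the 3 values shown sits).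

Compound 4, `Cc1c(F)c(Oc2cccc(CC(N)=O)c2)nc(Oc2cccc(C(=N)N)c2)c1F`, has not yet been measured. It differs from compound 3 in one place: carbamoylmethyl in place of 1H-imidazol-1-yl on an aromatic carbon. Among the measured compounds shown here, two measured steps bear on this change. The step of a 2.5-fold higher number from compound 2 to compound 3 (0.40 log units; beyond the scatter) shows that replacing a group bearing a hydrogen-bond donor by the imidazolyl group raised the number modestly; the step of an at least 1.0-fold lower number from compound 1 to compound 3 (0.01 log units; that floor lies within the scatter) shows no clear difference to carboxy. Since the entering carbamoylmethyl group again carries one hydrogen-bond donor, a modest lower number is expected, a 1.7-fold lower number from compound 3 to compound 4 (0.23 log units; within the scatter). Compound 4 is therefore estimated at 2800 nM, within a range of 1100 nM to 8000 nM.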

Compound 4, inhibition constant: > 5000 nM
Compound 4 was reported as a limit; the forecaster's own chance of this, stated with the estimate: 25%; middle value at least 1.7-fold (0.25 log units) away from the limit.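

In this assay, compound 4 is reported only as a limit, as compound 1 is: the limit of > 5000 nM in this assay, at which 2 of the 4 values shown sit.

Replacing methanesulfonamido with carbamoylmethyl gives an at least 2.6-fold higher number from compound 2 to compound 4 (0.42 log units; beyond the scatter), so a hydrogen-bond donor on the entering group does not on its own match compound 2, which now stands apart, beyond the scatter, from all three other compounds. Replacing 1H-imidazol-1-yl with carbamoylmethyl gives an at least 1.0-fold higher number from compound 3 to compound 4 (0.01 log units; that floor lies within the scatter), a floor that cannot be told from the scatter, and the step between the two limit compounds cannot be read at all.

Since compound 4 has no exact number, the compounds shown cannot say how much weaker it is than compound 3, if it is weaker at all, nor why methanesulfonamido stands apart from the other groups at this position. An acetamido group, which like methanesulfonamido joins the ring through nitrogen, and a longer chain such as carbamoylethyl would help show whether the link to the ring or the sulfonyl part goes with the lower number of compound 2.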